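The source may report more compounds than this note shows. Statements on the series, on what has been measured and on what is new or still open speak of the compounds shown alone.

In a functional assay on HT-1080 cells (Homo sapiens), read by transwell migration, with a stated time of 24 h, tested at 1 uM (on this read-out higher numbers stand for a weaker effect at the one concentration tested and lower numbers for a stronger effect), three compounds have been measured so far. Compound 1 `CC(=O)OCc1ccc2oc(=O)c(C(=O)Sc3cccc(Br)c3)cc2c1` gives 70.9%, compound 2 `CC(=O)OCc1ccc2oc(=O)c(C(=O)N(C)c3ccccc3Cl)cc2c1` gives 62.8%, and compound 3 `O=C(Oc1ccccc1)c1cc2cc([N+](=O)[O-])ccc2oc1=O` gives 76.7%, the highest of the three numbers, though its gap to compound 1 lies within the scatter and only compound 2 sits beyond the scatter below it. Compound 4 `O=C(Oc1cccc(I)c1)c1cc2cc([N+](=O)[O-])ccc2oc1=O` differs from compound 3 in one place: iodo in place of hydrogen on an aromatic carbon. Going by the values given here, the only measured step, a number 8.1 percentage points lower from compound 1 to compound 2 (within the scatter), exchanges the group on the carbonyl carbon rather than a ring hydrogen, so it gives no direct guide to adding iodo. With nothing pointing to a shift, no step beyond the scatter is expected, and the estimated step is a number 1.7 percentage points lower from compound 3 to compound 4 (within the scatter). Compound 4 is therefore expected to give about 75%, between 62% and 88%.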

Compound 4, a percentage reported as activity, at one concentration (the size of the read-out at that concentration, not a potency): 63.6%
Beside the measured number, compound 4's estimate is 11.4 percentage points above it; measured number inside the range.
By their numbers in this assay, from the lowest: compounds 2, 4, 1 and 3 (each within the scatter of the next, the first and the last beyond it).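

Iodo in place of hydrogen on an aromatic carbon, meta to a large group, is the first change at a ring hydrogen here. In this assay it gives a number 13.1 percentage points lower from compound 3 to compound 4 (beyond the scatter), which means a stronger effect at the one concentration tested, so a single iodine atom at this place of the phenoxy group is enough to move the read-out. Nothing at hand gives a reason for this step.

Going by these compounds, whether this shift belongs to iodo itself remains open, as a methoxy group, an amine or a carboxylic acid at the same carbon could show. So does whether iodo on another carbon of that ring would act alike.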